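A few compounds are considered here, and "the series" means these few. Any claim that something is new, unique, unknown or untested is made for them only; others in the source may bear on it.

Measured so far in a functional assay on MCF7 cells (Homo sapiens) for cytotoxicity, read by MTT assay, with a stated time of 24 h; a lower number here means a stronger inhibitor, a higher number a weaker inhibitor:
compound 1 `Cn1nc(-c2nnc(SCc3c(F)cccc3F)o2)cc1-c1ccc(C(F)(F)F)cc1` — compound 1 gives 26200 nM
compound 2 `Cn1nc(-c2nnc(SCCOc3ccccc3F)o2)cc1-c1ccc(C(F)(F)F)cc1` — compound 2 gives 23100 nM
compound 3 `Cn1nc(-c2ccc(C(F)(F)F)cc2)cc1-c1nnc(SCc2c(F)cccc2F)o1` — compound 3 gives 46200 nM

Compound 4 `Cn1nc(-c2ccc(C(F)(F)F)cc2)cc1-c1nnc(SCCOc2ccccc2F)o1` has not yet been measured in this assay. Compound 3 and compound 1 are built from the same atoms joined differently; the difference between the two cores is not broken down here. Compound 1 and compound 2 differ by (2-fluorophenoxy)methyl in place of 2,6-difluorophenyl on a saturated chain carbon bound to a sulfur, and that change gave a 1.1-fold lower number from compound 1 to compound 2 (0.05 log units; within the scatter). The same change, at the same place, leads from compound 3 to compound 4: (2-fluorophenoxy)methyl in place of 2,6-difluorophenyl on a saturated chain carbon bound to a sulfur. Within the data shown here, a step of similar size is expected, resting on the single measured example a 1.1-fold lower number from compound 1 to compound 2 (0.05 log units; within the scatter), which stayed within the scatter. The expected step is a 1.1-fold lower number from compound 3 to compound 4 (0.04 log units; within the scatter). Compound 4 is therefore estimated at about 42000 nM, most likely falling between 20000 nM and 90000 nM. Among the measured compounds shown here, only one prior instance of this change exists, so the expectation rests on a narrow base.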

Compound 4, half-maximal inhibitory concentration: 33300 nM
Compound 4: the middle estimate sits 1.3-fold (0.10 log units) above what was measured, within the range that was stated.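

In this assay, the swap of 2,6-difluorobenzyl for 2-(2-fluorophenoxy)ethyl gives a 1.4-fold lower number from compound 3 to compound 4 (0.14 log units; within the scatter). The change carries across the two cores with no difference that can be told apart: the same change on two cores in this assay, a 1.1-fold lower number (0.05 log units; within the scatter) from compound 1 to compound 2 and a 1.4-fold lower number (0.14 log units; within the scatter) from compound 3 to compound 4, 1.2-fold (0.09 log units) apart, within the scatter of two such steps. Among these compounds, both steps lie within the scatter and there is one pair per core, so this shows only that the change does little on these two cores, not that it would stay this small on any other core.

The compounds shown leave open what an amine, a carboxylic acid or a longer chain would do on the saturated chain bound to the sulfur. All four also keep the trifluoromethyl group, so a nitrile or methoxy group in its place remains an open question.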